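Methyl for trifluoromethoxy on the aryl ring of compound 2

The source may report more compounds than this note shows. Statements on the series, on what has been measured and on what is new or still open speak of the compounds shown alone.

Of the compounds shown here, two sharing one core have been measured in an assay on membranes from Sf9 cells for displacement of a labelled ligand from histamine H2 receptor (Homo sapiens), read by scintillation counting, with a stated time of 60 min; a higher number here means a weaker inhibitor, a lower number a stronger inhibitor. Compound 1 `Cc1nc(N)sc1CCCN/C(N)=N/C(=O)NC(C)c1ccccc1F` gives 28.8 nM in this assay. Compound 2 `Cc1nc(N)sc1CCCN/C(N)=N/C(=O)NC(C)c1ccc(OC(F)(F)F)cc1` gives 126 nM in this assay, the higher of the two numbers, and the gap between compound 2 and compound 1 lies beyond the usual scatter. Compound 3 `Cc1ccc(C(C)NC(=O)/N=C(\N)NCCCc2sc(N)nc2C)cc1` has not yet been measured. It differs from compound 2 in one place: methyl in place of trifluoromethoxy on an aromatic carbon. Among the measured compounds shown here, no measured pair shows this change, so its size is unknown. Because compound 2 sits at 126 nM, a modest step toward a lower number is expected for compound 3, perhaps only just beyond the scatter, so that the expected step is a 2.1-fold lower number from compound 2 to compound 3 (0.32 log units; beyond the scatter). Compound 3 is estimated at 60 nM in this assay, within a range from 20 nM to 180 nM.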

Compound 3, inhibition constant: 30.9 nM
Beside the measured number, compound 3's estimate is 1.9-fold (0.29 log units) above it; the range from low to high includes it.
By their numbers in this assay, from the lowest: compounds 1 and 3 (each within the scatter of the next); then compound 2.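

In this assay, methyl in place of trifluoromethoxy on an aromatic carbon para to a large group gives a 4.1-fold lower number from compound 2 to compound 3 (0.61 log units; beyond the scatter), so this position responds to the group it carries, with 1 heavy atom entering where 5 leave. The change of ring substitution also gives a 1.1-fold higher number from compound 1 to compound 3 (0.03 log units; within the scatter), which shows that 4-methylphenyl and 2-fluorophenyl on this core cannot be told apart in this measurement, whereas the trifluoromethoxy compound stands apart from both. Nothing available here accounts for the step at this position.

Two groups at this position cannot show whether the number follows the size of the group or some other feature of it. As far as these compounds go, how a hydroxyl, an amine or a carboxylic acid would read at the same aromatic carbon remains open.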